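Adding a methyl carbamate to the sulfonyl chain

This account rests on a few compounds, and the source may have more. Where it says the series, first, only, none or still open, it means among the compounds named here.

Of the compounds shown here, three sharing one core have been measured in a physicochemical assay for permeability, using PAMPA, at pH 7.4; on this read-out higher numbers stand for higher permeability and lower numbers for lower permeability. Compound 2 `CCS(=O)(=O)NC(=O)c1ccc(Nc2nc(NC3(c4ccc(Cl)cc4)CC3)nc(OCC(F)(F)F)n2)cc1` gives 28 nm/s. Compound 1 `CC(C)C(=O)NCCS(=O)(=O)NC(=O)c1ccc(Nc2nc(NC3(c4ccc(Cl)cc4)CC3)nc(OCC(F)(F)F)n2)cc1` gives 13 nm/s, and compound 3 `CNC(=O)NCCS(=O)(=O)NC(=O)c1ccc(Nc2nc(NC3(c4ccc(Cl)cc4)CC3)nc(OCC(F)(F)F)n2)cc1` gives 40 nm/s. Compound 2 thus stands second highest of the three, nearest to compound 3 and furthest from compound 1.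

Compound 4 `COC(=O)NCCS(=O)(=O)NC(=O)c1ccc(Nc2nc(NC3(c4ccc(Cl)cc4)CC3)nc(OCC(F)(F)F)n2)cc1` differs from compound 2 in one place: (methoxycarbonyl)amino in place of hydrogen on a saturated chain carbon, two bonds along the chain from a sulfonyl sulfur. Among the compounds with values here, two measured steps bear on this. Going from compound 2 to compound 3 attaches a (methylcarbamoyl)amino group at the same place, and a 1.4-fold higher number from compound 2 to compound 3 (0.15 log units; within the scatter). Going from compound 2 to compound 1 attaches an (isopropylcarbonyl)amino group there; read backwards, a 2.2-fold higher number from compound 1 to compound 2 (0.33 log units; beyond the scatter), so that attachment lowered the number. The entering group in compound 4 lies between these two cases in its make-up, so for compound 4 a step of a 1.2-fold lower number from compound 2 to compound 4 (0.07 log units; within the scatter) in this assay is expected, small and likely within the scatter, leaning downward. Compound 4 is therefore estimated at 24 nm/s, with a range from 12 nm/s to 48 nm/s.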

Compound 4, apparent permeability: 39 nm/s
Compound 4: the middle estimate sits 1.6-fold (0.21 log units) below what was measured; the range from low to high includes it.
By their numbers in this assay, from the lowest: compound 1; then compounds 2, 4 and 3 (each within the scatter of the next).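

Attaching the (methoxycarbonyl)amino group to the saturated chain carbon in this assay gives a step within the scatter (a 1.4-fold higher number from compound 2 to compound 4 (0.14 log units; within the scatter)), and methoxy in place of methylamino on the carbonyl carbon gives another (a 1.0-fold lower number from compound 3 to compound 4 (0.01 log units; within the scatter)). Within the data shown here, the only step here beyond the scatter is methoxy in place of isopropyl on that carbonyl carbon (a 3.0-fold higher number from compound 1 to compound 4 (0.48 log units; beyond the scatter)), so compound 1, with its isopropyl, stands lowest of the four, while compounds 2, 3 and 4 cannot be told apart. Nothing available explains why the isopropyl compound differs.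

As far as these compounds go, whether this gap belongs to isopropyl alone remains open, and an ethyl or a cyclopropyl on the carbonyl carbon would bear on that. Also open, from the compounds shown here alone, is how a free amine, a carboxylic acid or a longer chain carrying the (methoxycarbonyl)amino group would read.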